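The source may hold more compounds than are shown below. What is called first, only, known or untested is meant among the compounds shown, and "the series" means these compounds.

Measured compounds:
compound 1 `CC(C)(C)c1ccc(C(=O)N2CCC3(CC2)C(=O)N(CC(=O)N2CCC(O)CC2)CN3c2ccccc2)cc1` — 4700 nM
compound 2 `CCOC(=O)C1CCN(C(=O)CN2CN(c3ccccc3)C3(CCN(C(=O)c4ccc(C(C)(C)C)cc4)CC3)C2=O)CC1` — 3100 nM
compound 3 `CC(C)(C)OC(=O)NCC1CCN(C(=O)CN2CN(c3ccccc3)C3(CCN(C(=O)c4ccc(C(C)(C)C)cc4)CC3)C2=O)CC1` — 4200 nM

All three were run in an assay on HEK293 cells for displacement of a labelled ligand from NPC1-like intracellular cholesterol transporter 1 (Homo sapiens); on this read-out lower numbers stand for stronger inhibition and higher numbers for weaker inhibition. Compound 3 stands second highest of the three numbers; its nearest neighbour is compound 1 and the furthest is compound 2, and both gaps lie within the scatter. The three share one core and differ only in the group carried on a saturated ring carbon of the six-membered ring with one nitrogen. The steps among them are a 1.5-fold lower number from compound 1 to compound 2 (0.18 log units; within the scatter), a 1.1-fold lower number from compound 1 to compound 3 (0.05 log units; within the scatter) and a 1.4-fold higher number from compound 2 to compound 3 (0.13 log units; within the scatter), none of them beyond the scatter.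

Compound 4 `CCc1nn(CC)c(C2CCN(C(=O)CN3CN(c4ccccc4)C4(CCN(C(=O)c5ccc(C(C)(C)C)cc5)CC4)C3=O)CC2)c1CC` is the next member, not yet measured. It differs from compound 3 by 1,3,4-triethyl-1H-pyrazol-5-yl in place of ((tert-butoxycarbonyl)amino)methyl on a saturated ring carbon. The three measured steps all bear on this position, and each left the number essentially unchanged, so the same is expected here, although the entering group is an aromatic ring rather than an open chain and the comparison is therefore looser. The step expected is a 1.1-fold lower number from compound 3 to compound 4 (0.02 log units; within the scatter). Compound 4 is estimated at 4000 nM, with a range from 1500 nM to 11000 nM.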

Compound 4, half-maximal inhibitory concentration: 4600 nM
The estimate for compound 4 lay 1.2-fold (0.06 log units) below the measured number, within the range that was stated.
By their numbers in this assay, from the lowest: compounds 2, 3, 4 and 1 (each within the scatter of the next).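

In this assay, an aromatic ring on this saturated ring carbon is no more separated from the earlier groups than they are from each other: 1,3,4-triethyl-1H-pyrazol-5-yl gives a 1.1-fold higher number from compound 3 to compound 4 (0.04 log units; within the scatter), a 1.5-fold higher number from compound 2 to compound 4 (0.17 log units; within the scatter) and a 1.0-fold lower number from compound 1 to compound 4 (0.01 log units; within the scatter). The earlier compounds shown here carried only hydroxy and open-chain groups here, so the flat picture at this position now extends to a five-membered aromatic ring with 2 hetero atoms. Nothing at hand bears on why this position responds so little.

On these data alone, it remains open whether a primary amine or a carboxylic acid on this ring carbon would give a step beyond the scatter. Also open, as far as these compounds go, is whether a pyrazole without the three ethyl groups, or a plain phenyl ring, would fall within the same scatter.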